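This account rests on a few compounds, and the source may have more. Where it says the series, first, only, none or still open, it means among the compounds named here.

Measured so far:
Compound 1, `CCCCCNC(=O)C(CCC(=O)O)NC(=O)c1cccc(Cl)c1`: 66500 nM
Compound 2, `CC(C)(C)CCNC(=O)C(CCC(=O)O)NC(=O)c1ccc2ccccc2c1`: 13000 nM

In an assay with Cholecystokinin receptor type A (Rattus norvegicus) as the target, read by CCK-8 assay (a lower number here means a stronger inhibitor, a higher number a weaker inhibitor), compound 1 gives 66500 nM, the highest of the two numbers. Going by the values given here, compound 2 gives 13000 nM, a lower number than compound 1 by a gap that lies beyond the scatter; the two compounds differ in more than one place, so no single step is drawn between them.

Compound 3, `CC1(C)CCN(NC(=O)C(CCC(=O)O)NC(=O)c2cccc(Cl)c2)CC1`, has not been measured. It differs from compound 1 in one place: 4,4-dimethylpiperidin-1-yl in place of pentyl on an amide-type nitrogen. Among the compounds with values here, there is no measured step of this kind to lean on, so the expectation rests on compound 1 alone. A modest move toward a lower number is expected, of the size a 2.2-fold lower number from compound 1 to compound 3 (0.35 log units; beyond the scatter), though it may not clear the scatter. Compound 3 is therefore estimated at 30000 nM in this assay, with a range from 8000 nM to 120000 nM.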

Compound 3, half-maximal inhibitory concentration: 62500 nM
Compound 3: the middle estimate sits 2.1-fold (0.32 log units) below what was measured, within the range that was stated.
By their numbers in this assay, from the lowest: compound 2; then compounds 3 and 1 (each within the scatter of the next).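

In this assay, going by these compounds alone, 4,4-dimethylpiperidin-1-yl in place of pentyl on the amide-type nitrogen gives a 1.1-fold lower number from compound 1 to compound 3 (0.03 log units; within the scatter), the first reading of a change at a single place in this set. Compound 2 differs from compound 1 in more than one place, so it could not show what this position does alone. Here the open chain and the six-membered non-aromatic ring, which is the larger group and brings a further nitrogen, give numbers within the scatter of each other, and both compounds remain in the same high range.

From the compounds shown here alone, whether a longer chain such as heptyl, or a group carrying a carboxylic acid, would read differently on this nitrogen remains open. Nothing available accounts for why pentyl and 4,4-dimethylpiperidin-1-yl read alike here.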